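The compounds below may be only part of what the source reports. "The series", "measured", "known", "first", "only" and "open" are said of these compounds alone.

Compound 1 `CC(C)c1onc(-c2c(Cl)cccc2Cl)c1COc1ccc(N(C)C(=O)c2cccc(C(=O)O)c2)c(C(F)(F)F)n1` gives 35% in a functional assay on HEK293 cells for agonist activity at Bile acid receptor (Homo sapiens); on this read-out higher numbers stand for larger maximal responses and lower numbers for smaller maximal responses. Compound 2 `CC(C)c1onc(-c2c(Cl)cccc2Cl)c1COc1ccc(N(C)Cc2cccc(C(=O)O)c2)c(C(F)(F)F)n1` gives 89%. Compound 3 `CC(C)c1onc(-c2c(Cl)cccc2Cl)c1COc1ccc(N(C)Cc2cccc(C(=O)NS(C)(=O)=O)c2)c(C(F)(F)F)n1` gives 59%.

Among these three numbers compound 3 stands second highest: compound 1 lies below it, and the step of a number 30 percentage points lower from compound 2 to compound 3 (beyond the scatter) places compound 2 above it. Compound 4 `CC(C)c1onc(-c2c(Cl)cccc2Cl)c1COc1ccc(N(C)Cc2cccc(C(=O)NCCOP(=O)(O)O)c2)c(C(F)(F)F)n1` has not yet been measured. It differs from compound 3 in one place: a group of 7 heavy atoms (2 carbon, 4 oxygen, 1 phosphorus; no ring) in place of a group of 4 heavy atoms (1 carbon, 2 oxygen, 1 sulfur; no ring), on an amide-type nitrogen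

For the measured compounds named here, only one measured step touches this part of the molecule. The step of a number 30 percentage points lower from compound 2 to compound 3 (beyond the scatter) changed what sits on the carbonyl carbon, and that change lowered the response. The step of a number 54 percentage points higher from compound 1 to compound 2 (beyond the scatter) concerns a different region and says nothing about this one. Going by the values given here, no measured pair shows a methylsulfonyl group being exchanged for a phosphorus-bearing chain on an amide-type nitrogen, so the direction of the coming step is open. A step of modest size in either direction is the most that these data support, and the expectation for compound 4 is therefore a response near that of compound 3, given as a number 4 percentage points lower from compound 3 to compound 4 (within the scatter). Compound 4 is estimated at 55%, with a range from 35% to 80%.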

Compound 4, largest response reached (reported as efficacy), in percent of the reference or control that the assay uses: 48%
Estimate against measurement, compound 4: 7 percentage points above; the range from low to high includes it.
By their numbers in this assay, from the lowest: compound 1; then compound 4; then compound 3; then compound 2.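

In this assay, the hydroxy on the carbonyl carbon of the carboxylic acid can be replaced by a much longer group, but the response falls, with a number 41 percentage points lower from compound 2 to compound 4 (beyond the scatter) as the result. That fall is larger than the one seen with methanesulfonamido in compound 3, so the two replacements on this carbonyl carbon are not equivalent. On the amide-type nitrogen itself, the phosphorus-bearing chain in place of methylsulfonyl gives a number 11 percentage points lower from compound 3 to compound 4 (beyond the scatter) and thus shows that the group on this nitrogen affects the maximal response, although no measurement here explains either fall.

Going by these compounds, a plain amide or a tetrazole in place of the carboxylic acid remains open. So does a chain on the amide-type nitrogen that ends in a carboxylic acid or a hydroxyl group rather than the phosphorus-bearing end.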